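Methyl added to the shared core: cytotoxicity outlook

The source may hold more compounds than are shown below. What is called first, only, known or untested is meant among the compounds shown, and "the series" means these compounds.

Working notes on the series. Compound 1 `Clc1ccc(-c2ccc3ccccc3n2)c(Cl)c1` stands at the top of the two measured numbers: in a functional assay on HepG2 cells (Homo sapiens) for cytotoxicity, read by MTT assay, with a stated time of 48 h (on this read-out higher numbers stand for weaker inhibition and lower numbers for stronger inhibition), compound 1 gives 31600 nM. Compound 2 `Nc1ccc(-c2ccc3ccc(Cl)cc3n2)cc1` is the nearest neighbour; in this assay compound 2 gives 11000 nM, a lower number than that of compound 1 by a margin beyond the scatter. Compound 3 `Cc1ccc2nc(-c3ccc(Cl)cc3Cl)ccc2c1` differs from compound 1 in a single place: methyl in place of hydrogen on an aromatic carbon. Going by the values given here, no step of this kind between measured compounds is available, so the size of the change has no anchor in the data. The expected step is small, a 1.3-fold lower number from compound 1 to compound 3 (0.10 log units; within the scatter), at most within the scatter and more likely downward than upward. Compound 3 is therefore expected to give 25000 nM in this assay, with a range from 10000 nM to 60000 nM.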

Compound 3, half-maximal inhibitory concentration: > 50000 nM
Compound 3: only a limit was reported; the forecaster's own chance of this, stated with the estimate: 15%; middle value at least 2.0-fold (0.30 log units) from the limit.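

In this assay compound 3 gives > 50000 nM, which is a limit of the assay and not a number. Methyl in place of hydrogen on an aromatic carbon now has its first anchor in the series, an at least 1.5-fold higher number from compound 1 to compound 3 (0.19 log units; that floor lies within the scatter), so at this place the only reading available gives the change no gain in cytotoxicity. The direction can be read only as far as the floor allows, and the true size of the step stays unknown because one end of it is a limit: the limit of > 50000 nM in this assay, at which 1 of the 3 values shown sits.

From the compounds shown here alone, whether an amine or a carboxylic acid on the same aromatic carbon would bring the number in this assay down remains open. Also open, going by these compounds, is whether methyl on other carbons of the shared core would act as it does here.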